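This account rests on a few compounds, and the source may have more. Where it says the series, first, only, none or still open, it means among the compounds named here.

Measured compounds:
compound 1, `CN1CCN(c2nc(N)nc(COc3cccc(Cl)c3)n2)CC1`, in an assay on HEK293 cells for displacement of a labelled ligand from 5-hydroxytryptamine receptor 6 (Homo sapiens), read by radioligand binding, with a stated time of 1 h; on this read-out lower numbers stand for stronger inhibition and higher numbers for weaker inhibition: 148 nM
compound 2, `Cc1ccccc1OCc1nc(N)nc(N2CCN(C)CC2)n1`, in this assay: 87 nM
compound 3, `Cc1cccc(OCc2nc(N)nc(N3CCN(C)CC3)n2)c1`, in this assay: 207 nM

Compound 3 gives the highest number of the three. Its nearest neighbour is compound 1: a 1.4-fold higher number from compound 1 to compound 3 (0.15 log units; within the scatter), a swap of methyl for chloro on the aromatic ring that stays within the scatter. Its furthest is compound 2: a 2.4-fold higher number from compound 2 to compound 3 (0.38 log units; beyond the scatter), where the methyl sits at a different position of the phenyl ring and the number shifts beyond the scatter. The remaining step, a 1.7-fold lower number from compound 1 to compound 2 (0.23 log units; within the scatter), is also within the scatter.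

Compound 4, `Cc1cc(OCc2nc(N)nc(N3CCN(C)CC3)n2)ccc1Cl`, has not yet been measured in this assay. It differs from compound 3 by chloro in place of hydrogen on an aromatic carbon, so the aryl ether becomes 4-chloro-3-methylphenyl. Going by the values given here, the only measured step that bears on chloro is a 1.4-fold higher number from compound 1 to compound 3 (0.15 log units; within the scatter), where chloro and methyl on the phenyl ring trade places without leaving the scatter; no measured pair carries both chloro and methyl on that ring, so the combined substitution has no direct precedent. On that basis compound 4 is expected to move little, with the step of a 1.4-fold lower number from compound 3 to compound 4 (0.14 log units; within the scatter) estimated as modest and, if anything, toward a lower number. Compound 4 is therefore estimated in this assay at 150 nM, within a range of 60 nM to 400 nM.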

Compound 4, inhibition constant: 355 nM
For compound 4 the middle estimate is 2.4-fold (0.37 log units) below the measured one, and the stated range covers the measured number.
By their numbers in this assay, from the lowest: compounds 2, 1, 3 and 4 (each within the scatter of the next, the first and the last beyond it).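

In this assay chloro on the aromatic carbon ortho to the methyl group and para to a large group gives a 1.7-fold higher number from compound 3 to compound 4 (0.23 log units; within the scatter) and so cannot be told from the scatter, which shows that this ring position accepts chloro on the 3-methylphenyl group without a clear step. The ring carrying both chloro and methyl does separate from the single-substituent rings, with a 4.1-fold higher number from compound 2 to compound 4 (0.61 log units; beyond the scatter) against 2-methylphenyl and a 2.4-fold higher number from compound 1 to compound 4 (0.38 log units; beyond the scatter) against 3-chlorophenyl, whereas compound 3 had stayed within the scatter of compound 1. No measurement at hand accounts for these numbers.

The compounds shown leave open whether a methoxy group, a nitrile or a bromo group at this position would read like chloro, and whether 4-chlorophenyl without the methyl group would stand with compound 3 or with compound 4. Also open, on these data alone, is how chloro would read on the 2-methylphenyl ring of compound 2, since every chloro-bearing ring here lacks a methyl group on that carbon or carries its methyl group elsewhere.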